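Series notes: nitrofuran amide cytotoxicity, compound 3 to compound 4

A few compounds are considered here, and "the series" means these few. Any claim that something is new, unique, unknown or untested is made for them only; others in the source may bear on it.

Three compounds of the series have been run in an ADME assay on Vero cells (Chlorocebus sabaeus) for cytotoxicity, read by MTT assay, with a stated time of 72 h; a higher number here means a weaker inhibitor, a lower number a stronger inhibitor. Compound 1 `COc1cccc(-c2csc(NC(=O)c3ccc([N+](=O)[O-])o3)n2)c1` gives 58700 nM, compound 2 `COc1ccccc1-c1csc(NC(=O)c2ccc([N+](=O)[O-])o2)n1` gives 42000 nM and compound 3 `CC(C)Oc1cccc(-c2csc(NC(=O)c3ccc([N+](=O)[O-])o3)n2)c1` gives 69500 nM, the highest of the three numbers, though every gap among them is within the scatter: a 1.4-fold lower number from compound 1 to compound 2 (0.15 log units; within the scatter) and a 1.2-fold higher number from compound 1 to compound 3 (0.07 log units; within the scatter). Compound 4 `O=C(Nc1nc(-c2cccc(NC(=O)C3CCCCC3)c2)cs1)c1ccc([N+](=O)[O-])o1` carries (cyclohexylcarbonyl)amino in place of isopropoxy on an aromatic carbon. Among the measured compounds shown here, no measured step exchanges an oxygen-linked group for an amide-linked one; the nearest precedent, the change from compound 1 to compound 3 on the same oxygen, stayed within the scatter. For compound 4 no shift beyond the scatter is therefore expected in this assay, a 1.2-fold lower number from compound 3 to compound 4 (0.06 log units; within the scatter). The estimate for compound 4 is 60000 nM, within 25000 nM to 150000 nM.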

Compound 4, half-maximal inhibitory concentration: 21900 nM
For compound 4 the middle estimate is 2.7-fold (0.44 log units) above the measured one; the whole stated range lies above it.
By their numbers in this assay, from the lowest: compounds 4, 2, 1 and 3 (each within the scatter of the next, the first and the last beyond it).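

In this assay this position, which showed nothing beyond the scatter while only the group on the oxygen changed, does respond: (cyclohexylcarbonyl)amino in place of isopropoxy gives a 3.2-fold lower number from compound 3 to compound 4 (0.50 log units; beyond the scatter) and, in place of methoxy, gives a 2.7-fold lower number from compound 1 to compound 4 (0.43 log units; beyond the scatter) with both steps modest. Among the steps so far, only this exchange of an oxygen-linked group for the amide-linked group with its six-membered ring moves the number beyond the scatter. Nothing available accounts for the shift.

From the compounds shown here alone, whether the cyclohexane ring or the amide link carries the shift stays open. A small acetylamino group or a free amine at the same place would separate the two.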